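The source may hold more compounds than are shown below. What is called first, only, known or untested is meant among the compounds shown, and "the series" means these compounds.

Working notes on the series.

Compound 1 `c1ccc(-c2cccc(Cn3ccnc3)c2)cc1` is the reference point. In an in vitro assay on V79MZ cells for inhibition of cytochrome P450 11B2, mitochondrial (Homo sapiens) (on this read-out lower numbers stand for stronger inhibition and higher numbers for weaker inhibition), compound 1 gives 265 nM, the lowest of the two numbers in hand; the nearest is compound 2 `c1ccc(-c2cc(Cn3ccnc3)cc(-c3ccccc3)c2)cc1`, which in this assay gives 332 nM. Going by the values given here, the one measured step, a 1.3-fold higher number from compound 1 to compound 2 (0.10 log units; within the scatter), is within the scatter, so the two measured compounds cannot be ordered.

Compound 3 `Cc1cccc(Cn2ccnc2)c1` differs from compound 1 by methyl in place of phenyl on an aromatic carbon. Among the compounds with values here, no measured step covers this change directly. Within the data shown here, the only step in hand, a 1.3-fold higher number from compound 1 to compound 2 (0.10 log units; within the scatter), concerns a phenyl that enters elsewhere on the same core and leaves the number essentially where it was. That step offers little guidance for a phenyl that leaves and a methyl that enters; the direction of the effect for compound 3 is therefore open, and a moderate shift in either direction, or none beyond the scatter, remains possible.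

On balance the expectation for compound 3 is a step of a 2.3-fold higher number from compound 1 to compound 3 (0.35 log units; beyond the scatter), with a wide range: compound 3 is estimated at 600 nM, between 150 nM and 2500 nM.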

Compound 3, half-maximal inhibitory concentration: 110 nM
Beside the measured number, compound 3's estimate is 5.5-fold (0.74 log units) above it, and the stated range ends above it.
By their numbers in this assay, from the lowest: compound 3; then compounds 1 and 2 (each within the scatter of the next).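

In this assay, methyl in place of phenyl on this aromatic carbon, meta to a (1H-imidazol-1-yl)methyl group, gives a 2.4-fold lower number from compound 1 to compound 3 (0.38 log units; beyond the scatter) and so moves the number beyond the scatter, which the earlier step, a 1.3-fold higher number from compound 1 to compound 2 (0.10 log units; within the scatter), did not do. The change is modest, but it shows that the read-out responds to the group at this position and that the phenyl, with its 6 heavy atoms and six-membered aromatic ring, is not required for a number at this level, since a methyl of 1 heavy atom gives a lower one. The data in hand offer no measured basis for explaining this shift.

From the compounds shown here alone, what remains open is how far this trend extends at the same position: an ethyl, a longer chain, a methoxy group, a chlorine or an amine could each continue the step, cancel it or reverse it. Going by these compounds, it is also open whether a methyl in place of phenyl would give a similar step on the core of compound 2, which carries a further phenyl.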